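The source may report more compounds than this note shows. Statements on the series, on what has been measured and on what is new or still open speak of the compounds shown alone.

Measured compounds:
compound 1, `Cc1cc(Nc2cc(-c3cccs3)[nH]n2)n2nc(SCc3ccc(Br)cc3)nc2n1`, 4890 nM
compound 2, `CCCCCc1c(C)nc2nc(SCc3ccc(Cl)cc3)nn2c1Nc1cc(-c2ccccc2)[nH]n1`, value given as a limit > 50000 nM
compound 3, `Cc1cc(Nc2cc(-c3ccccc3)[nH]n2)n2nc(SCc3ccccc3Br)nc2n1`, 5630 nM

The assay throughout is a functional assay on PC-9 cells (Homo sapiens) for inhibition, read by MTT assay, with a stated time of 72 h; on this read-out lower numbers stand for stronger inhibition and higher numbers for weaker inhibition. Compound 1 gives 4890 nM. Compound 2 reaches only the limit of this assay, > 50000 nM, so no number is known for it; this is the limit of > 50000 nM in this assay, at which 1 of the 3 values shown sits. Compound 3 gives 5630 nM, which lies within the usual scatter of the number for compound 1, so the two cannot be told apart.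

Compound 4, `Cc1cc(Nc2cc(-c3ccccc3)[nH]n2)n2nc(SCc3csc4ccccc34)nc2n1`, has not yet been measured. It differs from compound 3 in one place: 1-benzothiophen-3-yl in place of 2-bromophenyl on a saturated chain carbon bound to a sulfur. Within the data shown here, no pair of measured compounds here differs in only one place, so there is no measured step to lean on; only the three numbers above are known. A change of this kind, swapping one ring for a larger two-ring group at the same attachment point, is expected to move the number little, with no clear direction.

For compound 4 the expected value is 6000 nM, with a likely range from 2000 nM to 20000 nM. The expected step is a 1.1-fold higher number from compound 3 to compound 4 (0.03 log units; within the scatter), not beyond the scatter.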

Compound 4, half-maximal inhibitory concentration: 4420 nM
Estimate against measurement, compound 4: 1.4-fold (0.13 log units) above, and the stated range covers the measured number.
By their numbers in this assay, from the lowest: compounds 4, 1 and 3 (each within the scatter of the next). At a limit, above all of these: compound 2.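

In this assay, putting 1-benzothiophen-3-yl in place of 2-bromophenyl on a saturated chain carbon bound to a sulfur gives a 1.3-fold lower number from compound 3 to compound 4 (0.11 log units; within the scatter), so compound 3 and compound 4 cannot be told apart. Among these compounds, this is the first measured step here that changes only one place, and it shows that a two-ring group with 9 heavy atoms, one of them sulfur, gives a number no different from that of a single ring carrying bromine. Nothing measured here accounts for this similarity.

As far as these compounds go, both groups at this position are aromatic and have no hydrogen-bond donors, so it remains open what an amine or a carboxylic acid would do there. A plain alkyl chain in place of the ring is equally untested among the compounds shown.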